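Swapping chloro for methoxy on an aromatic carbon

A few compounds are considered here, and "the series" means these few. Any claim that something is new, unique, unknown or untested is made for them only; others in the source may bear on it.

Compound 1 `O=C(NO)c1cnc(N2C[C@H]3CN(Cc4cc(Cl)cc(Cl)c4)C[C@H]3C2)nc1` gives 940 nM
Compound 2 `O=C(NO)c1cnc(N2C[C@H]3CN(Cc4ccc(Cl)cc4)C[C@H]3C2)nc1` gives 690 nM
Compound 3 `COc1ccc(CN2C[C@@H]3CN(c4ncc(C(=O)NO)cn4)C[C@@H]3C2)cc1` awaits measurement

Among the measured compounds shown here, in a functional assay on HeLa cells (Homo sapiens) for inhibition, read by sulforhodamine B assay, with a stated time of 72 h (on this read-out lower numbers stand for stronger inhibition of growth and higher numbers for weaker inhibition of growth), compound 2 stands with compound 1 as the only other measured compound, and the two values lie within the scatter of each other. Compound 3 differs from compound 2 at one place (methoxy in place of chloro on an aromatic carbon), with methoxy in place of chloro on an aromatic carbon. For the measured compounds named here, no measured step makes this exact change. The nearest guide is a 1.4-fold lower number from compound 1 to compound 2 (0.13 log units; within the scatter) where the change also falls on the aromatic ring of the benzyl group. On these data alone, on that single step, no change beyond the scatter is expected in this assay and the direction stays open. The estimate for compound 3 is 650 nM as an expected value, with an expected range from 300 nM to 1400 nM in this read-out. This estimate means a 1.1-fold lower number from compound 2 to compound 3 (0.03 log units; within the scatter) as the expected step.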

Compound 3, concentration for 50% growth inhibition: 950 nM
Compound 3: middle estimate off by 1.5-fold (0.16 log units), on the low side; measured number inside the range.
By their numbers in this assay, from the lowest: compounds 2, 1 and 3 (each within the scatter of the next).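

Moving from 4-chlorobenzyl to 4-methoxybenzyl puts a group other than chloro on this aromatic carbon, one with two heavy atoms and a hydrogen-bond acceptor, and in this assay the result is a 1.4-fold higher number from compound 2 to compound 3 (0.14 log units; within the scatter). The comparison with the dichlorinated benzyl group gives a 1.0-fold higher number from compound 1 to compound 3 (0.00 log units; within the scatter), so all three benzyl groups shown lie within the scatter of one another, and neither this exchange nor the earlier one separates them in this assay. No available evidence bears on this result.

On these data alone, whether an amine, a hydroxyl or a longer chain such as butoxy on this same aromatic carbon would move the number beyond the scatter remains open. Also open, as far as these compounds go, is whether a carboxylic acid there would leave growth inhibition where these three compounds stand.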